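The compounds below may be only part of what the source reports. "The series", "measured", "known", "first", "only" and "open" are said of these compounds alone.

Compound 1 `COc1cc(C2Oc3cc([C@H]4Oc5cc(O)cc(O)c5C(=O)[C@@H]4O)ccc3OC2COC(=O)c2cccc(Cl)c2)ccc1O`: in a functional assay, read by spectrophotometry, with a stated time of 30 min (on this read-out higher numbers stand for an effect only at larger amounts of compound and lower numbers for an effect already at smaller amounts), compound 1 gives 106000 nM.
Compound 2 `COc1cc(C2Oc3cc([C@H]4Oc5cc(O)cc(O)c5C(=O)[C@@H]4O)ccc3OC2COC(=O)c2cc([N+](=O)[O-])cc([N+](=O)[O-])c2)ccc1O`: in this assay compound 2 gives 205000 nM.

Compound 2 holds the larger of the two numbers, yet the step of a 1.9-fold higher number from compound 1 to compound 2 (0.29 log units; within the scatter) is within the scatter, so the two compounds are not told apart. Compound 3 `CCOC(=O)CC(=O)OCC1Oc2ccc([C@H]3Oc4cc(O)cc(O)c4C(=O)[C@@H]3O)cc2OC1c1ccc(O)c(OC)c1` differs in (ethoxycarbonyl)methyl in place of 3,5-dinitrophenyl on a carbonyl carbon. Going by the values given here, the only measured step at this carbonyl carbon, a 1.9-fold higher number from compound 1 to compound 2 (0.29 log units; within the scatter), swapped one aryl group for another and stayed within the scatter; no measured step exchanges an aryl group for a chain. Compound 3 is therefore expected to remain near compound 2 in this assay, with no shift beyond the scatter. The expected step is a 1.4-fold lower number from compound 2 to compound 3 (0.14 log units; within the scatter). Compound 3 is estimated at 150000 nM, between 60000 nM and 400000 nM.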

Compound 3, half-maximal effective concentration: 101000 nM
Estimate against measurement, compound 3: 1.5-fold (0.17 log units) above; measured number inside the range.
By their numbers in this assay, from the lowest: compounds 3, 1 and 2 (each within the scatter of the next, the first and the last beyond it).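

In this assay, going by these compounds alone, a chain on this carbonyl carbon can now be set against aryl groups: (ethoxycarbonyl)methyl in place of 3,5-dinitrophenyl gives a 2.0-fold lower number from compound 2 to compound 3 (0.31 log units; beyond the scatter) and is the first step here beyond the scatter, though a modest one. The same chain in place of 3-chlorophenyl gives a 1.0-fold lower number from compound 1 to compound 3 (0.02 log units; within the scatter) and does not tell the two compounds apart, so among these compounds an aromatic ring at this place is not required for a number in this range. No measurement on hand accounts for either step.

Still open, going by these compounds, is whether an amine, a carboxylic acid or a longer chain on this carbonyl carbon would move the number beyond the scatter, and in which direction.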